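The source may report more compounds than this note shows. Statements on the series, on what has been measured and on what is new or still open speak of the compounds shown alone.

Measured so far:
Compound 1, `CC(C)C[C@@H]1NC(=O)[C@H](Cc2cnc[nH]2)NC1=O`: 0%
Compound 2, `CC(C)C[C@@H]1NC(=O)[C@H](CCC(=O)O)NC1=O`: 0%
Compound 3, `CC(C)C[C@@H]1NC(=O)[C@H](CCCCN)NC1=O`: 0%

In a functional assay, tested at 2.5 mM (a higher number here means more inhibition at the concentration tested (going by the name of the read-out), a lower number less inhibition), compound 3 gives 0%, level with compounds 1 and 2. The steps leading to it, no change at the digits printed from compound 1 to compound 3 (within the scatter) and no change at the digits printed from compound 2 to compound 3 (within the scatter), swap the side chain on the same saturated chain carbon bound to a saturated ring carbon, and neither moves the read-out; the same holds for no change at the digits printed from compound 1 to compound 2 (within the scatter). Compound 4, `CC(C)C[C@@H]1NC(=O)[C@H](CC(N)=O)NC1=O`, continues this series of side-chain swaps: carbamoyl in place of 3-aminopropyl on a saturated chain carbon bound to a saturated ring carbon. Going by the values given here, no measured step exchanges these exact groups, but every swap at this place so far has left the read-out unchanged, so the expected step is no change at the digits printed from compound 3 to compound 4 (within the scatter), none beyond the scatter. For compound 4 the estimated value is 0%, in a range from 0% to 10%.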

Compound 4, a percentage reported as inhibition, at one concentration (the size of the read-out at that concentration, not a potency): 0%
Beside the measured number, compound 4's estimate shows no gap at the digits printed; the measured number falls inside the stated range.
By their numbers in this assay, from the lowest: compounds 1, 2, 3 and 4 (each within the scatter of the next).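

At this saturated chain carbon bound to a saturated ring carbon, carbamoyl joins the swaps that leave this assay unmoved: no change at the digits printed from compound 3 to compound 4 (within the scatter), no change at the digits printed from compound 2 to compound 4 (within the scatter) and no change at the digits printed from compound 1 to compound 4 (within the scatter). With compound 4 also at 0%, this side chain gives no basis for ranking the four compounds. Nothing available explains this result. On these data alone, whether a benzyl group or a longer chain ending in a guanidine at this place would give any inhibition remains open.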